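Amide aryl exchange from compound 3 to compound 4

The compounds below may be only part of what the source reports. "The series", "measured", "known", "first", "only" and "open" are said of these compounds alone.

Measured so far in a toxicity assay on HepG2 cells (Homo sapiens) for inhibition, read by CellTiter-Glo, with a stated time of 48 h; a lower number here means a stronger inhibitor, a higher number a weaker inhibitor:
compound 1 `COc1ccc2nc(C)cc(OCC(=O)Nc3cc(C)cc(C)c3)c2c1` gives 20000 nM.
compound 2 `COc1ccc2nc(C)cc(OCC(=O)Nc3cc(F)cc(F)c3)c2c1` gives only a limit of the assay, > 100000 nM.
compound 3 `COc1ccc2nc(C)cc(OCC(=O)Nc3ccc(F)cc3)c2c1` gives 63100 nM.

Among the two numbers given, compound 3 sits highest; its nearest neighbour is compound 1, with a 3.2-fold higher number from compound 1 to compound 3 (0.50 log units; beyond the scatter). Against compound 2 the step is an at least 1.5-fold lower number from compound 2 to compound 3 (0.19 log units; that floor lies within the scatter). Compound 4 `COc1ccc2nc(C)cc(OCC(=O)Nc3ccccn3)c2c1` differs from compound 3 by pyridin-2-yl in place of 4-fluorophenyl on an amide-type nitrogen. Among the measured compounds shown here, the steps that bear on it are the two aryl exchanges on the same amide-type nitrogen, a 3.2-fold higher number from compound 1 to compound 3 (0.50 log units; beyond the scatter) and an at least 1.5-fold lower number from compound 2 to compound 3 (0.19 log units; that floor lies within the scatter): one modest, one within the scatter, and no pyridin-2-yl group appears among the measured compounds. In this assay the change is therefore expected to give a step of no more than modest size, a 1.1-fold higher number from compound 3 to compound 4 (0.05 log units; within the scatter), with the direction uncertain. Compound 4 is estimated at 70000 nM, with a range from 25000 nM to 200000 nM.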

Compound 4, half-maximal inhibitory concentration: > 100000 nM
Compound 4 gave a limit, no number; the forecaster's own chance of this, stated with the estimate: 30%; at least 1.4-fold (0.15 log units) between middle value and limit.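

In this assay, compound 4 gives only a limit of the assay, as compound 2 does, so the step between them cannot be read. The readable steps are an at least 1.5-fold higher number from compound 3 to compound 4 (0.19 log units; that floor lies within the scatter) and an at least 5.0-fold higher number from compound 1 to compound 4 (0.69 log units; beyond the scatter), so the pyridin-2-yl group gives no number, and it stays well clear of the 3,5-dimethylphenyl result of compound 1. Further separation among the weakest aryl groups on this amide-type nitrogen is cut off by the assay ceiling: the limit of > 100000 nM in this assay, at which 2 of the 4 values shown sit.

As far as these compounds go, how far compound 4 lies past that limit remains open. Also open, from the compounds shown here alone, is whether pyridin-3-yl or 4-methylphenyl on the same nitrogen would return a number.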